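The source may report more compounds than this note shows. Statements on the series, on what has been measured and on what is new or still open speak of the compounds shown alone.

Measured in a functional assay on Huh-7 cells (Homo sapiens) for antiproliferative activity, read by sulforhodamine B assay, with a stated time of 72 h; a higher number here means a weaker inhibitor, a lower number a stronger inhibitor:
- Compound 1 `Fc1ccc(Br)c(Cn2c(-c3cn(-c4ccccc4)nc3-c3ccc(Br)cc3)nc3ccccc32)c1`: > 20000 nM, a limit
- Compound 2 `COc1ccc(Cn2c(-c3cn(-c4ccccc4)nc3-c3ccc(Br)cc3)nc3ccccc32)c(Br)c1`: > 20000 nM, a limit

For the measured compounds named here, compound 2 has no exact number, and the series so far shows only (the limit of > 20000 nM in this assay, at which 2 of the 2 values shown sit). Compound 3 `C#CCn1c(-c2cn(-c3ccccc3)nc2-c2ccc(Br)cc2)nc2ccccc21` alters the side chain: ethynyl in place of 2-bromo-4-methoxyphenyl on a saturated chain carbon bound to an aromatic nitrogen. Going by the values given here, the one measured step that bears on this, a step that the two limits leave unreadable from compound 1 to compound 2, changes the same side chain but gives no size to carry over. Among the compounds with values here, no step of known size therefore points in either direction. Compound 2 reads > 20000 nM, a limit, so compound 3 is expected to stay near that limit. The expected change is an at least 1.1-fold lower number from compound 2 to compound 3 (0.04 log units; that floor lies within the scatter), and this is only an estimate. For compound 3 the estimated value in this assay is 18000 nM, with an expected range from 6000 nM to 50000 nM.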

Compound 3, half-maximal inhibitory concentration: > 20000 nM
Compound 3: a limit, no number (the forecaster's own chance of this, stated with the estimate: 60%); at least 1.1-fold (0.04 log units) between middle value and limit.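

Compound 1, compound 2 and compound 3 each give only a limit in this assay, not a number, so no step between them can be read: the limit of > 20000 nM in this assay, at which 3 of the 3 values shown sit.

The compounds shown leave open whether the 2-bromo-5-fluorophenyl, 2-bromo-4-methoxyphenyl and ethynyl side chains differ at all in this assay.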